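The source may hold more compounds than are shown below. What is called first, only, known or untested is meant among the compounds shown, and "the series" means these compounds.

For the measured compounds named here, in a functional assay on SHEP cells (Homo sapiens) for antiproliferative activity, read by spectrophotometry and resazurin assay, with a stated time of 72 h (a lower number here means a stronger inhibitor, a higher number a weaker inhibitor), compound 1 `CC(C)CC(=O)CC1Oc2cc(O)ccc2C=C1c1ccc(O)cc1` gives 139000 nM and compound 2 `O=C(CC1Oc2cc(O)ccc2C=C1c1ccc(O)cc1)c1ccccc1` gives 102000 nM, so compound 1 stands within the scatter of the only other number available. Compound 3 `COc1ccc(C(=O)CC2Oc3cc(O)ccc3C=C2c2ccc(O)cc2)cc1` keeps the core of compound 1 and has 4-methoxyphenyl in place of isobutyl on a carbonyl carbon. Going by the values given here, one measured step bears on this change, phenyl in place of isobutyl on a carbonyl carbon, which gives a 1.4-fold lower number from compound 1 to compound 2 (0.13 log units; within the scatter) for compound 2. Among the compounds with values here, no measured compound shows a 4-methoxyphenyl group on that carbonyl carbon, so this single small step is the only guide. In this assay, therefore, no step beyond the scatter is expected, and the expected step is a 1.4-fold lower number from compound 1 to compound 3 (0.14 log units; within the scatter). The estimated value for compound 3 is 100000 nM, with an expected range from 50000 nM to 190000 nM.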

Compound 3, half-maximal inhibitory concentration: 37000 nM
The estimate for compound 3 lay 2.7-fold (0.43 log units) above the measured number; measured number outside the range, below it.
By their numbers in this assay, from the lowest: compound 3; then compounds 2 and 1 (each within the scatter of the next).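

In this assay, the group on the carbonyl carbon now shifts the number beyond the scatter: 4-methoxyphenyl in place of isobutyl gives a modest drop (a 3.8-fold lower number from compound 1 to compound 3 (0.57 log units; beyond the scatter)), which phenyl in place of isobutyl did not give (a 1.4-fold lower number from compound 1 to compound 2 (0.13 log units; within the scatter)). Methoxy in place of hydrogen on an aromatic carbon also gives a modest drop by itself (a 2.8-fold lower number from compound 2 to compound 3 (0.44 log units; beyond the scatter)), so among these three compounds the lower number appears only once the methoxy is present, not with the aromatic ring alone. No evidence is available that explains this difference.

From the compounds shown here alone, whether a hydroxyl, a chlorine or an amine on that aromatic carbon would lower the number as methoxy does remains open. The compounds shown also do not tell whether anything on this ring takes the number far below that of compound 3, which gives 37000 nM.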